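Moving a fluorine on the N-aryl ring of compound 3

The compounds below may be only part of what the source reports. "The series", "measured", "known", "first", "only" and "open" are said of these compounds alone.

Measured compounds:
- Compound 1 `Cn1c(=O)c(C(=O)Nc2ccc(Oc3ccncc3-c3cccnc3)c(F)c2)nn(-c2c(Cl)cccc2Cl)c1=O`: 3930 nM
- Compound 2 `Cn1c(=O)c(C(=O)Nc2ccc(Oc3ccncc3-c3cccnc3)c(F)c2)nn(-c2ccc(F)c(Cl)c2)c1=O`: 10100 nM
- Compound 3 `O=C(Nc1ccc(Oc2ccncc2-c2cccnc2)c(F)c1)c1nn(-c2cccc(F)c2)c(=O)c2ccccc12`: 27 nM

In a functional assay on MKN-45 cells (Homo sapiens) for cytotoxicity, read by MTT assay, with a stated time of 72 h (on this read-out higher numbers stand for weaker inhibition and lower numbers for stronger inhibition), compound 3 gives 27 nM, the lowest number of the three, with compound 1 at 3930 nM and compound 2 at 10100 nM far behind. Compound 3 has a different core from compounds 1 and 2, so its lead over them cannot be traced to the aryl group on the aromatic nitrogen alone.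

Compound 4 `O=C(Nc1ccc(Oc2ccncc2-c2cccnc2)c(F)c1)c1nn(-c2ccc(F)cc2)c(=O)c2ccccc12` has not yet been measured in this assay. It differs from compound 3 only in that ring: 4-fluorophenyl in place of 3-fluorophenyl on an aromatic nitrogen. Going by the values given here, the one measured step that also changes the aryl group on an aromatic nitrogen is a 2.6-fold higher number from compound 1 to compound 2 (0.41 log units; beyond the scatter), a change of two substituents at once, on the other core. A shift of a single fluorine from one position to another is a smaller change than that, so the expected step is a 1.3-fold higher number from compound 3 to compound 4 (0.11 log units; within the scatter), within or close to the scatter. Compound 4 is therefore estimated at 35 nM, most likely between 12 nM and 110 nM.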

Compound 4, half-maximal inhibitory concentration: 320 nM
Compound 4: the middle estimate sits 9.1-fold (0.96 log units) below what was measured; measured number above the stated range.
By their numbers in this assay, from the lowest: compound 3; then compound 4; then compound 1; then compound 2.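

In this assay, moving one fluorine on the ring attached to the aromatic nitrogen, with no atom gained or lost, is enough for a large change: 4-fluorophenyl in place of 3-fluorophenyl gives a 12-fold higher number from compound 3 to compound 4 (1.07 log units; beyond the scatter). The earlier step on the other core could not show this, since two substituents changed there at once; here, the place of a single fluorine on this ring is shown to matter by itself. No measurement available here accounts for the size of this step.

The compounds shown leave open whether an unsubstituted phenyl ring, or a methoxy group or an amine in place of the fluorine, would hold the number of compound 3 or lose it. On these data alone, it also remains open whether the same fluorine shift would have a similar effect on the core of compound 1.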